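Compound 2 to compound 4: hydrogen in place of methyl

A few compounds are considered here, and "the series" means these few. Any claim that something is new, unique, unknown or untested is made for them only; others in the source may bear on it.

Compound 1 (`CNC(=O)c1cc(C(=O)NC2CC2)n(Cc2ccccc2)n1`) gives 285 ug/mL in a physicochemical assay for solubility, read by HPLC, in simulated intestinal fluid, with a stated time of 16 h, at pH 6.5 (on this read-out higher numbers stand for higher solubility and lower numbers for lower solubility), as its solubility reading. Compound 3 (`CNC(=O)c1cc(C(=O)NC2CC2)cn([C@@H](C)c2ccccc2)c1=O`) gives 699 ug/mL in this assay on the same read-out. Compound 2 (`CNC(=O)c1cc(C(=O)N[C@H]2CC[C@H](O)CC2)c([C@@H](C)c2cccc(C)c2)o1`) gives > 1000 ug/mL in this assay and this is a limit, not a number. The position of compound 2 is thus the limit of > 1000 ug/mL in this assay, at which 1 of the 3 values shown sits, and no exact figure exists for it.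

The change from compound 2 to compound 4 (`CNC(=O)c1cc(C(=O)N[C@H]2CC[C@H](O)CC2)c([C@@H](C)c2ccccc2)o1`) is hydrogen in place of methyl on an aromatic carbon and reads as hydrogen in place of methyl on an aromatic carbon, with 3-methylphenyl turning into phenyl. For the measured compounds named here, no pair of measured compounds isolates this change, so the series offers no direct measure of it. The expected size of the change in this assay is none beyond the scatter, in neither direction. The expectation leans on compound 2 with > 1000 ug/mL as its limit. The expected figure for the step is a step that the limit leaves unreadable from compound 2 to compound 4 and it is read against a starting point that is only a limit. A result for compound 4 reported again as a limit would fit this expectation. The estimated solubility in this assay for compound 4 is 1100 ug/mL within an expected range from 600 ug/mL to 2000 ug/mL as the working figure.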

Compound 4, solubility: 827 ug/mL
The estimate for compound 4 lay 1.3-fold (0.12 log units) above the measured number; the range from low to high includes it.
By their numbers in this assay, from the lowest: compound 1; then compounds 3 and 4 (each within the scatter of the next). At a limit, above all of these: compound 2.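

Compound 2 gives > 1000 ug/mL in this assay, which is a limit and not a number, so until now the core of compound 2 had no exact solubility figure. Compound 4, with phenyl in place of 3-methylphenyl, gives 827 ug/mL in this assay and is the only compound shown with an exact figure on this core. Hydrogen in place of methyl on an aromatic carbon gives an at least 1.2-fold lower number from compound 2 to compound 4 (0.08 log units; that floor lies within the scatter), and this figure is only a floor because the starting point is a limit: the limit of > 1000 ug/mL in this assay, at which 1 of the 4 values shown sits.

Going by these compounds, the true size of this step remains open: the floor shows no change beyond the scatter, but it does not exclude a larger one. Also open is how the same place on the six-membered aromatic ring would read in this assay with a group such as an amine, a carboxylic acid or a longer chain in place of hydrogen or methyl, since the compounds shown cover only these two.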